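The source may hold more compounds than are shown below. What is called first, only, known or untested is meant among the compounds shown, and "the series" means these compounds.

Compound 1 `Oc1ccc(-c2cc(-c3ccc(Cl)cc3)nc(-c3ccccn3)c2)cc1` and compound 2 `Oc1ccc(-c2cc(-c3ccc(Cl)cc3)nc(-c3cccnc3)c2)cc1` share one core and differ only in the ring attached beside the core nitrogen. In a functional assay on DU-145 cells (Homo sapiens) for cytotoxicity, read by CCK-8 assay and cell counting, with a stated time of 2 days (a lower number here means a stronger inhibitor, a higher number a weaker inhibitor), compound 1 gives 22500 nM, and compound 2 gives 22800 nM, so the two sit side by side, with the step of a 1.0-fold higher number from compound 1 to compound 2 (0.01 log units; within the scatter) inside the usual scatter. Compound 3 `Oc1ccc(-c2cc(-c3ccc(Cl)cc3)nc(-c3ccco3)c2)cc1` is not yet measured; it differs from compound 2 by furan-2-yl in place of pyridin-3-yl on an aromatic carbon. Among the compounds with values here, only that one step bears on this change, and it was flat, so no step beyond the scatter is expected. Compound 3 is estimated at 20000 nM, in the range 8000 nM to 50000 nM, meaning an expected step of a 1.1-fold lower number from compound 2 to compound 3 (0.06 log units; within the scatter).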

Compound 3, half-maximal inhibitory concentration: 7280 nM
The estimate for compound 3 lay 2.7-fold (0.44 log units) above the measured number; the whole stated range lies above it.
By their numbers in this assay, from the lowest: compound 3; then compounds 1 and 2 (each within the scatter of the next).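

In this assay the ring at this position can move the number after all: furan-2-yl gives a 3.1-fold lower number from compound 2 to compound 3 (0.50 log units; beyond the scatter) and also a 3.1-fold lower number from compound 1 to compound 3 (0.49 log units; beyond the scatter) for this swap. So the flat step between pyridin-2-yl and pyridin-3-yl did not mean that every ring here behaves alike. No measurement at hand explains why the furan-2-yl compound differs.
From the compounds shown here alone, whether the change follows the smaller five-membered ring or its oxygen stays open, since one furan-2-yl ring cannot separate the two. A thiophen-2-yl ring, with sulfur in place of oxygen, or a plain phenyl ring could help tell them apart.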